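Taking the acetyl off a biphenyl EP4 ligand

The source may report more compounds than this note shows. Statements on the series, on what has been measured and on what is new or still open speak of the compounds shown alone.

Measured compounds:
compound 1 `CC(=O)c1ccc(-c2ccc(OCc3cc(C(=O)O)oc3C)cc2)cc1`: 150 nM
compound 2 `COc1ccc(-c2ccc(OCc3cc(C(=O)NS(=O)(=O)c4c(C)noc4C)oc3C)cc2)nc1`: 13 nM

In an assay on cells for displacement of a labelled ligand from prostaglandin E2 receptor EP4 subtype (Homo sapiens), read by scintillation counting (on this read-out higher numbers stand for weaker inhibition and lower numbers for stronger inhibition), compound 1 gives 150 nM and compound 2 gives 13 nM, so compound 1 stands as the higher of the two numbers, the weaker inhibitor. Compound 3 `Cc1oc(C(=O)O)cc1COc1ccc(-c2ccccc2)cc1` is not yet measured. It differs from compound 1 in one place: hydrogen in place of acetyl on an aromatic carbon. Going by the values given here, no measured pair shows this change, so the step is a guess: the expected step of a 2.7-fold higher number from compound 1 to compound 3 (0.43 log units; beyond the scatter) is a modest rise in the number, beyond the scatter. Compound 3 is expected to give about 400 nM, within 120 nM to 1500 nM.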

Compound 3, inhibition constant: 420 nM
Compound 3: middle estimate off by 1.1-fold (0.02 log units), on the low side, within the range that was stated.
By their numbers in this assay, from the lowest: compound 2; then compound 1; then compound 3.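

In this assay, replacing the acetyl with hydrogen gives a 2.8-fold higher number from compound 1 to compound 3 (0.45 log units; beyond the scatter), so the group at this place, para to a large group, does affect the number. The change is modest, though: compound 3 still gives 420 nM with no group there at all, so the acetyl is not essential for a measurable value. Nothing shown explains this rise.

On these data alone, whether an amine or a nitrile at this place would give a lower number than the acetyl remains open. So does whether a longer chain there would match it.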